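This account rests on a few compounds, and the source may have more. Where it says the series, first, only, none or still open, it means among the compounds named here.

Compound 1 `Cc1cn([C@@H]2O[C@H](CO[Si](C)(C)C(C)(C)C)[C@@]3(OS(=O)(=O)C=C3N)[C@H]2O[Si](C)(C)C(C)(C)C)c(=O)n(C(=O)c2ccccc2)c1=O` and compound 2 `Cc1cn([C@@H]2O[C@H](CO[Si](C)(C)C(C)(C)C)[C@@]3(OS(=O)(=O)C=C3N)[C@H]2O[Si](C)(C)C(C)(C)C)c(=O)n(C(=O)C2CC2)c1=O` share the same core and differ only in the group on a carbonyl carbon. In an ADME assay on Huh-7 cells (Homo sapiens) for cytotoxicity, with a stated time of 72 h (a lower number here means that less compound is tolerated, a higher number that more compound is tolerated), compound 1 gives only a limit of the measurement, > 100000 nM. In this assay compound 2 likewise gives a limit, > 100000 nM. Among the compounds with values here, the single measured step, a step that the two limits leave unreadable from compound 1 to compound 2, thus has no readable size, since both values sit at the limit of > 100000 nM in this assay, at which 2 of the 2 values shown sit. Compound 3 `CNC(=O)CCCC(=O)n1c(=O)c(C)cn([C@@H]2O[C@H](CO[Si](C)(C)C(C)(C)C)[C@@]3(OS(=O)(=O)C=C3N)[C@H]2O[Si](C)(C)C(C)(C)C)c1=O` is the next member: 3-(methylcarbamoyl)propyl in place of cyclopropyl on a carbonyl carbon. Within the data shown here, no measured step tells what a change of this kind does to tolerance, and the two existing values are limits rather than numbers; in this assay the change is expected to be a step that the limit leaves unreadable from compound 2 to compound 3, most likely again ending at a limit. Compound 3 is accordingly estimated to give 150000 nM in this assay, within a range from 50000 nM to 500000 nM.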

Compound 3, half-maximal cytotoxic concentration: > 100000 nM
Compound 3 was reported as a limit (the forecaster's own chance of this, stated with the estimate: 85%); the middle value is on the limit's open side.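

Within the data shown here, compound 3 gives only a limit in this assay, as do compound 1 and compound 2, so no step among the three can be read: the limit of > 100000 nM in this assay, at which 3 of the 3 values shown sit. The compounds shown leave open whether phenyl, cyclopropyl or 3-(methylcarbamoyl)propyl on the carbonyl carbon makes any difference to how much compound the cells tolerate.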